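The source may hold more compounds than are shown below. What is called first, only, known or untested is meant among the compounds shown, and "the series" means these compounds.

In a functional assay on the whole organism (strain Wistar CF) for inhibition, with Rattus norvegicus as the target, read by paw edema, with stated times of 1 h and 2 h, at a dose of 100 mg/kg by the oral route (a lower number here means less inhibition, a higher number more inhibition at the dose given (going by the name of the read-out)), compound 1 `COc1ccc(/C=N/c2ccc(OC(=O)C(C)c3ccc(CC(C)C)cc3)cc2)cc1` gives 56.2% and compound 2 `CC(C)Cc1ccc(C(C)C(=O)Oc2ccc(/N=C/c3ccc(N(C)C)cc3)cc2)cc1` gives 96.1%.

Compound 2 stands highest of the two, and a number 39.9 percentage points higher from compound 1 to compound 2 (beyond the scatter) sets that gap beyond the scatter. Compound 3 `CC(C)Cc1ccc(C(C)C(=O)Oc2ccc(/N=C/c3ccc(Br)cc3)cc2)cc1` differs from compound 2 by bromo in place of dimethylamino on an aromatic carbon. Among the compounds with values here, no measured step covers bromo at this position; the only known step swaps methoxy for dimethylamino, so the effect of losing dimethylamino is uncertain, and a drop of unknown size is the more likely direction. Compound 3 is therefore expected at 62% (range 35% to 90%), an estimated step of a number 34.1 percentage points lower from compound 2 to compound 3 (beyond the scatter).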

Compound 3, a percentage reported as inhibition, in the whole organism at one dose (the size of the read-out at that dose, not a potency): 40.6%
For compound 3 the middle estimate is 21.4 percentage points above the measured one; the measured number falls inside the stated range.
By their numbers in this assay, from the lowest: compound 3; then compound 1; then compound 2.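

In this assay, the group on this aromatic carbon has a large effect on the result: replacing dimethylamino with bromo removes the high inhibition (a number 55.5 percentage points lower from compound 2 to compound 3 (beyond the scatter)). The loss goes beyond the methoxy compound too (a number 15.6 percentage points lower from compound 1 to compound 3 (beyond the scatter)), so the three groups rank dimethylamino, then methoxy, then bromo. Nothing available explains this order. As far as these compounds go, whether another amine, such as a simple amino group or diethylamino, would keep the high inhibition remains open. So does the effect of a carboxylic acid here.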